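This account rests on a few compounds, and the source may have more. Where it says the series, first, only, none or still open, it means among the compounds named here.

Measured so far:
Compound 1 `Cc1cc2c(c(Oc3cccc(NS(=O)(=O)c4ccc(Cl)cc4)c3)n1)C(=O)NC2=O` gives 109% in a functional assay on HEK293 cells for agonist activity at Glucose-dependent insulinotropic receptor (Homo sapiens), read by cAMP accumulation, with a stated time of 30 min; on this read-out higher numbers stand for larger maximal responses and lower numbers for smaller maximal responses.
Compound 2 `CCN1C(=O)c2cc(C)nc(Oc3cccc(NS(=O)(=O)c4ccc(Cl)cc4)c3)c2C1=O` gives 120% in this assay.

Compound 1 stands lowest of these two numbers. Its nearest neighbour is compound 2, which is reached by putting ethyl in place of hydrogen on an amide-type nitrogen in a ring; that step, a number 11 percentage points higher from compound 1 to compound 2 (beyond the scatter), lies beyond the usual scatter of such measurements.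

Compound 3 `Cc1cc2c(c(Oc3cccc(NS(=O)(=O)c4ccc(Cl)cc4)c3)n1)C(=O)N(C1CCCC1)C2=O` has not yet been measured. It differs from compound 1 in one place: cyclopentyl in place of hydrogen on an amide-type nitrogen in a ring. Within the data shown here, the only measured step that bears on this change is a number 11 percentage points higher from compound 1 to compound 2 (beyond the scatter), where a small saturated carbon group took the place of the same hydrogen. By analogy a modest rise in this assay is expected for compound 3, of roughly the same size, although the shown compounds hold no example of a ring-shaped group at this position, so the range must be kept wide.

Compound 3 is therefore estimated to give 118%, with a likely range from 100% to 135%, which means an expected step of a number 9 percentage points higher from compound 1 to compound 3 (within the scatter).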

Compound 3, largest response reached (reported as efficacy), in percent of the reference or control that the assay uses: 95%
Estimate against measurement, compound 3: 23 percentage points above; the whole stated range lies above it.
By their numbers in this assay, from the lowest: compound 3; then compound 1; then compound 2.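

In this assay, a group on the amide-type nitrogen in a ring does not simply raise the maximal response: ethyl in place of hydrogen gave a number 11 percentage points higher from compound 1 to compound 2 (beyond the scatter), whereas cyclopentyl in place of the same hydrogen brings a number 14 percentage points lower from compound 1 to compound 3 (beyond the scatter). Exchanging ethyl for cyclopentyl at this nitrogen gives a number 25 percentage points lower from compound 2 to compound 3 (beyond the scatter), so these two carbon groups are not interchangeable here, and the change at this position can move the response in either direction. No measurement offered here explains why the two groups differ in this way.

The compounds shown cannot separate the presence of a ring from the size of the group, since cyclopentyl differs from ethyl in both respects; a straight pentyl chain or a smaller cyclopropyl ring on the same nitrogen would help to tell these apart. They also leave open how a group of another kind at this nitrogen, such as a chain ending in an amine or a carboxylic acid, would compare with compound 1.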